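The source may report more compounds than this note shows. Statements on the series, on what has been measured and on what is new or still open speak of the compounds shown alone.

The series shares one core, carried by compound 1 `CC1(C)[C@H]2CC[C@]1(C)N(Cc1cn(-c3ccccc3O)nn1)C(=O)C2`, compound 2 `CC1(C)[C@H]2CC[C@]1(C)N(Cc1cn(-c3ccccc3C#N)nn1)C(=O)C2` and compound 3 `CC1(C)[C@H]2CC[C@]1(C)N(Cc1cn(-c3cccc(C#N)c3)nn1)C(=O)C2`. In a functional assay on LoVo cells (Homo sapiens) for inhibition, read by MTT assay, with a stated time of 24 h (on this read-out higher numbers stand for weaker inhibition and lower numbers for stronger inhibition), compound 1 gives 540 nM, compound 2 gives 140 nM and compound 3 gives 320 nM. Compound 2 holds the lowest number of the three; its nearest neighbour is compound 3, and the step of a 2.3-fold higher number from compound 2 to compound 3 (0.36 log units; beyond the scatter) lies beyond the scatter, as does a 3.9-fold lower number from compound 1 to compound 2 (0.59 log units; beyond the scatter). The step of a 1.7-fold lower number from compound 1 to compound 3 (0.23 log units; within the scatter) stays within the scatter.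

Compound 4 `CC1(C)[C@H]2CC[C@]1(C)N(Cc1cn(-c3ccc(O)cc3)nn1)C(=O)C2` is not yet measured. Its change from compound 2: 4-hydroxyphenyl in place of 2-cyanophenyl on an aromatic nitrogen. Among the compounds with values here, two measured steps bear on it. The step of a 3.9-fold lower number from compound 1 to compound 2 (0.59 log units; beyond the scatter) shows cyano in place of hydroxy giving a lower number, so the reverse exchange is expected to give a higher one. The step of a 2.3-fold higher number from compound 2 to compound 3 (0.36 log units; beyond the scatter) shows that the 3-cyanophenyl arrangement in place of 2-cyanophenyl also gives a higher number. Both pull the same way, and nothing measured here pulls against them. The expected step is therefore a 4.3-fold higher number from compound 2 to compound 4 (0.63 log units; beyond the scatter), a rise beyond the scatter. The estimate for compound 4 in this assay is 600 nM, with a range from 250 nM to 1500 nM.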

Compound 4, half-maximal inhibitory concentration: 410 nM
Compound 4: middle estimate off by 1.5-fold (0.17 log units), on the high side; measured number inside the range.
By their numbers in this assay, from the lowest: compound 2; then compounds 3, 4 and 1 (each within the scatter of the next).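

In this assay the 2-cyanophenyl of compound 2 now stands apart from a third group on the aromatic nitrogen, with a 2.9-fold higher number from compound 2 to compound 4 (0.47 log units; beyond the scatter), so compound 2 has the lowest number of the four, with its steps to all the others beyond the scatter. The 4-hydroxyphenyl does not separate from the other two groups: a 1.3-fold lower number from compound 1 to compound 4 (0.12 log units; within the scatter) and a 1.3-fold higher number from compound 3 to compound 4 (0.11 log units; within the scatter) both stay within the scatter, so among compounds 1, 3 and 4 neither the kind of group nor its place on the phenyl ring can be read, and only the nitrile in the 2-cyanophenyl arrangement stands out. No measured information is available to explain this difference.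

From the compounds shown here alone, whether the low number of compound 2 is tied to the nitrile itself remains open, as an amine, a carboxylic acid or a methoxy group in the 2-cyanophenyl arrangement would test that. Also open, going by these compounds, is whether the flat level shared by compounds 1, 3 and 4 holds for an unsubstituted phenyl or for a longer chain on the aromatic nitrogen.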